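Removing One Chain Double Bond from Compound 1

A few compounds are considered here, and "the series" means these few. Any claim that something is new, unique, unknown or untested is made for them only; others in the source may bear on it.

Values in a functional assay on MCF7 cells (Homo sapiens) for antiproliferative activity, read by MTT assay; on this read-out higher numbers stand for weaker inhibition and lower numbers for stronger inhibition:
- compound 1 `CC/C=C\C/C=C\C/C=C\CCCCCCCc1cc(=O)c2c(O)c(C)c(O)c(C)c2o1`: 17500 nM
- compound 2 `CC/C=C\C/C=C\C/C=C\CCCCCCCc1cc(=O)c2c(O)c(C)c(O)cc2o1`: 17500 nM
- compound 3 `CC/C=C\C/C=C\C/C=C\CCCCCCCc1cc(=O)c2c(O)c(C)c(OCOC)c(C)c2o1`: > 84100 nM (a limit, not a number)

Compound 1, at 17500 nM, stands level with compound 2 at the digits shown. The next compound, compound 4 `CCCCC/C=C\C/C=C\CCCCCCCc1cc(=O)c2c(O)c(C)c(O)c(C)c2o1`, keeps the shared core and differs only in the chain: butyl in place of but-1-en-1-yl on a saturated chain carbon bound to a double-bonded chain carbon.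

Neither measured step touches this chain. The step of no change at the digits printed from compound 1 to compound 2 (within the scatter) lies within the scatter, while the step of an at least 4.8-fold higher number from compound 1 to compound 3 (0.68 log units; beyond the scatter) rests on a limit, and both changes lie on the core. For the measured compounds named here, they therefore give no direct measure of the chain change, and the expectation is only that the shared core holds the read-out near that of compound 1 at 17500 nM. In this assay the expected step is no change at the digits printed from compound 1 to compound 4 (within the scatter), with none expected beyond the scatter. Compound 4 is estimated at 17500 nM. The expected range for compound 4 runs from 8000 nM to 40000 nM.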

Compound 4, half-maximal inhibitory concentration: > 84100 nM
Compound 4: a limit, no number (the forecaster's own chance of this, stated with the estimate: 10%); at least 4.8-fold (0.68 log units) between middle value and limit.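

Until this point only changes on the shared core had been seen in this assay, and compound 4 shows that the chain matters as well. Butyl in place of but-1-en-1-yl on a saturated chain carbon bound to a double-bonded chain carbon gives an at least 4.8-fold higher number from compound 1 to compound 4 (0.68 log units; beyond the scatter), so this one double bond cannot be lost without a clear change in the read-out, even with the core of compound 1 intact. The reading for compound 4 is a limit and not a number, so the full size of the step stays unknown: the limit of > 84100 nM in this assay, at which 2 of the 4 values shown sit.

From the compounds shown here alone, it remains open whether removing either of the two remaining chain double bonds would have the same outcome. Also open, going by these compounds, is how a shorter chain, a longer chain or a carboxylic acid at the chain end would read.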